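Swapping the pyridyl isomer on the ring nitrogen

This account rests on a few compounds, and the source may have more. Where it says the series, first, only, none or still open, it means among the compounds named here.

Three compounds of the shared core carry different aryl groups on the aromatic nitrogen: compound 1 `CCOC(=O)C1=C(C)N/C(=C/c2cc(C)n(-c3ccc(F)cc3F)c2C)C1=O`, compound 2 `CCOC(=O)C1=C(C)N/C(=C/c2cc(C)n(-c3ccc(SC)cc3)c2C)C1=O` and compound 3 `CCOC(=O)C1=C(C)N/C(=C/c2cc(C)n(-c3ccncc3)c2C)C1=O`. In an ADME assay on L6 cells (Rattus norvegicus) for cytotoxicity, read by resazurin assay, with a stated time of 72 h (a higher number here means that more compound is needed for the effect, a lower number that less compound is needed), compound 1 gives 14000 nM, compound 2 gives 54000 nM and compound 3 gives 100000 nM. Compound 3 holds the highest of the three numbers; one of the steps that lead to it, a 1.9-fold higher number from compound 2 to compound 3 (0.27 log units; within the scatter), lies within the scatter, while the other, a 7.1-fold higher number from compound 1 to compound 3 (0.85 log units; beyond the scatter), lies beyond it. The remaining step, a 3.9-fold higher number from compound 1 to compound 2 (0.59 log units; beyond the scatter), separates the two aryl groups that are not pyridines.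

Compound 4 `CCOC(=O)C1=C(C)N/C(=C/c2cc(C)n(-c3cccnc3)c2C)C1=O` differs from compound 3 by pyridin-3-yl in place of pyridin-4-yl on an aromatic nitrogen. Within the data shown here, none of the measured steps touches this change: each of them exchanges one aryl group for another of a different kind, whereas here the same six-membered aromatic ring with 1 hetero atom returns with its atoms joined differently. The measured steps therefore give no ground for a shift in either direction in this assay beyond the scatter. Compound 4 is expected to show a step of a 1.1-fold lower number from compound 3 to compound 4 (0.05 log units; within the scatter), no larger than the scatter. Compound 4 is estimated at 90000 nM, within a range of 35000 nM to 200000 nM.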

Compound 4, half-maximal effective concentration: 160000 nM
For compound 4 the middle estimate is 1.8-fold (0.25 log units) below the measured one; measured number inside the range.
By their numbers in this assay, from the lowest: compound 1; then compounds 2, 3 and 4 (each within the scatter of the next, the first and the last beyond it).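

In this assay, pyridin-3-yl in place of pyridin-4-yl on the aromatic nitrogen gives a step within the scatter (a 1.6-fold higher number from compound 3 to compound 4 (0.20 log units; within the scatter)), so the two pyridine isomers cannot be told apart at this position. The new isomer does, however, separate from 4-(methylsulfanyl)phenyl beyond the scatter (a 3.0-fold higher number from compound 2 to compound 4 (0.47 log units; beyond the scatter)), which the pyridin-4-yl group did not do, and its step from 2,4-difluorophenyl (an 11-fold higher number from compound 1 to compound 4 (1.06 log units; beyond the scatter)) is the only large one in the set, leaving compound 1 apart from both pyridines and from compound 2. No measurement at hand accounts for any of these steps.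

On these data alone, how pyridin-2-yl, or a phenyl ring carrying a carboxylic acid or a dimethylamino group, would behave on this aromatic nitrogen in this assay stays open. The two fluorines of 2,4-difluorophenyl also remain unseparated, so a 4-fluorophenyl group would be needed to show whether the lower number of compound 1 goes with the fluorine at the 4-position or requires both.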